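This account rests on a few compounds, and the source may have more. Where it says the series, first, only, none or still open, it means among the compounds named here.

Values in an ADME assay on RAW264.7 cells (Mus musculus) for cytotoxicity, read by MTT assay; a higher number here means a weaker inhibitor, a lower number a stronger inhibitor:
Compound 1 `CC(C)CCOc1cccc(O)c1C(=O)/C=C/c1ccc(O)cc1`: > 30000 nM
Compound 2 `CCCCCCCCCCCCCCCCOc1cccc(O)c1C(=O)/C=C/c1ccc(O)cc1`: > 30000 nM
Compound 3 `CCCCCCCCC(CCCCCC)CCOc1cccc(O)c1C(=O)/C=C/c1ccc(O)cc1`: > 30000 nM

In this assay, compound 1 stands at > 30000 nM, which is a limit of the assay and not a number. Compounds 2 and 3 stand there with it: the limit of > 30000 nM in this assay, at which 3 of the 3 values shown sit.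

Compound 4 `O=C(/C=C/c1ccc(O)cc1)c1c(O)cccc1OCc1ccccc1` has not yet been measured. It carries phenyl in place of isobutyl on a saturated chain carbon bound to an oxygen on an aromatic ring. Among the measured compounds shown here, no measured step is available to guide the estimate, but with the limit of > 30000 nM in this assay, at which 3 of the 3 values shown sit, no change beyond the scatter is expected. The estimated step, a number no higher from compound 1 to compound 4 (the limit leaves the size open), is expected to remain within the scatter. In this assay, the expected value for compound 4 is 30000 nM, estimated to lie between 15000 nM and 60000 nM.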

Compound 4, half-maximal inhibitory concentration: > 30000 nM
Compound 4: only a limit was reported; the forecaster's own chance of this, stated with the estimate: 75%; the middle value sits exactly at the limit.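

No new step can be read between compound 1 and compound 4: each stands at a limit in this assay and not at a number. In this assay the compounds shown leave open whether the different chains on the shared core differ at all.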